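The source may hold more compounds than are shown below. What is called first, only, known or untested is meant among the compounds shown, and "the series" means these compounds.

Measured so far in an assay on isolated protein for inhibition of 2-Hydroxyacid oxidase 2 (Homo sapiens), tested at 10 uM; a higher number here means a stronger effect of the compound at the concentration tested, a lower number a weaker effect:
compound 1, `Cc1n[nH]c(C(N)=O)c1Cc1cccc(-c2ccc(F)cc2)c1`, gives 14%
compound 2, `Cc1n[nH]c(C(=O)O)c1Cc1ccc(C(N)=O)cc1`, gives 8%
compound 3, `CCc1n[nH]c(C(=O)O)c1Cc1cccc(-c2ccc(F)cc2)c1`, gives 36%

Compound 3 stands highest of these three numbers. Its nearest neighbour is compound 1, whose number lies lower by a margin beyond the scatter, and the furthest is compound 2, lower still and also beyond the scatter. Going by the values given here, compound 1 and compound 3 differ in more than one place, as do compound 2 and compound 3, so no single step between any two measured compounds is drawn; only their values as such can be compared.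

The step followed here leads from compound 3 to compound 4, `CC(C)c1n[nH]c(C(=O)O)c1Cc1cccc(-c2ccc(F)cc2)c1`, which has not yet been measured in this assay. The change is: methyl in place of hydrogen on a saturated chain carbon bound to an aromatic carbon and a saturated chain carbon. Among the compounds with values here, no pair of measured compounds differs in this one place, so there is no measured step of this kind to lean on. The change adds a single carbon to a chain on the shared core, and the expectation is a step in this assay that is small, either upward or none beyond the scatter, with the step from compound 3 to compound 4 expected to be a number 4 percentage points higher from compound 3 to compound 4 (within the scatter). Compound 4 is accordingly estimated at 40%, with a range from 20% to 60%.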

Compound 4, a percentage reported as inhibition, at one concentration (the size of the read-out at that concentration, not a potency): 11%
The estimate for compound 4 lay 29 percentage points above the measured number; measured number below the stated range.
By their numbers in this assay, from the lowest: compounds 2, 4 and 1 (each within the scatter of the next); then compound 3.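

In this assay, going by these compounds alone, the change from ethyl to isopropyl gives the first step that can be read at this place, a number 25 percentage points lower from compound 3 to compound 4 (beyond the scatter). Within the data shown here, until now no two measured compounds differed in one place only, so the values could not show whether this chain responded to any single change; this step shows that it does, and that a single added methyl on a saturated chain carbon bound to an aromatic carbon and a saturated chain carbon is enough to lower the number beyond the scatter, with the rest of the structure unchanged. Nothing measured here bears on why the number falls with this one added carbon.

The compounds shown leave open whether the loss goes with the added carbon as such or with the way it is attached, which an unbranched propyl chain or a cyclopropyl ring at the same place would help to separate. They also leave open whether the same step would appear with a tetrazole in place of the carboxylic acid on the shared core.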